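From tert-Butyl to Benzyl on the Amide Nitrogen

This account rests on a few compounds, and the source may have more. Where it says the series, first, only, none or still open, it means among the compounds named here.

Compound 1, `CCN(CC)C(=O)CC1CCc2cc(OC)c(OC)cc21`: in a functional assay on the whole organism (strain Swiss albino) for inhibition, with Mus musculus as the target, in the writhing test, with stated times of 60 min and 15 min, at a dose of 100 mg/kg by the oral route (on this read-out higher numbers stand for more inhibition at the one dose given (going by the name of the read-out) and lower numbers for less inhibition), compound 1 gives 27.4%.
Compound 2, `COc1cc2c(cc1OC)C(CC(=O)NC(C)C)CC2`: in this assay compound 2 gives 29.3%.
Compound 3, `COc1cc2c(cc1OC)C(CC(=O)NC(C)(C)C)CC2`: in this assay compound 3 gives 41.8%.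

Compound 3 stands highest of the three on the numbers shown, and its steps to both other compounds lie beyond the scatter: a number 12.5 percentage points higher from compound 2 to compound 3 (beyond the scatter), and a number 14.4 percentage points higher from compound 1 to compound 3 (beyond the scatter). The step of a number 1.9 percentage points higher from compound 1 to compound 2 (within the scatter) lies within the scatter, so compounds 1 and 2 cannot be told apart on this read-out.

Compound 4, `COc1cc2c(cc1OC)C(CC(=O)NCc1ccccc1)CC2`, keeps the shared core and the amide and changes only the group on the amide-type nitrogen: benzyl in place of tert-butyl on an amide-type nitrogen. Among the compounds with values here, none of the measured steps exchanges an alkyl group for a benzyl group, so no step bears directly on this change. All three measured amides differ only in the substituent on the amide-type nitrogen, and the two steps beyond the scatter both lead to the (tert-butyl)amino compound 3. Within the data shown here, a secondary amide carrying a different group has no precedent here, and a step about the size of the measured ones, in either direction, cannot be ruled out. The account therefore expects compound 4 to show a step of a number 8.8 percentage points lower from compound 3 to compound 4 (within the scatter). The estimate for compound 4 in this assay is 33%, with an expected range from 18% to 50%.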

Compound 4, a percentage reported as inhibition, in the whole organism at one dose (the size of the read-out at that dose, not a potency): 48.1%
The estimate for compound 4 lay 15.1 percentage points below the measured number, and the stated range covers the measured number.
By their numbers in this assay, from the lowest: compounds 1 and 2 (each within the scatter of the next); then compounds 3 and 4 (each within the scatter of the next).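

In this assay the change on the amide-type nitrogen from tert-butyl to benzyl, which brings in a six-membered aromatic ring of carbon only, gives a number 6.3 percentage points higher from compound 3 to compound 4 (within the scatter), so compounds 3 and 4 cannot be told apart on this read-out and the higher level no longer rests on tert-butyl alone. Benzyl in place of isopropyl gives a number 18.8 percentage points higher from compound 2 to compound 4 (beyond the scatter), and benzylamino in place of diethylamino gives a number 20.7 percentage points higher from compound 1 to compound 4 (beyond the scatter), so compound 4 stands clear of those two amides just as compound 3 does, and this position is shown to take a group carrying a ring with no change beyond the scatter from tert-butyl. Nothing shown gives a reason for these steps.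

The compounds shown leave open whether the aromatic ring matters or only the larger group, a question that cyclohexylmethyl on the same nitrogen, or 2-phenylethyl with its longer chain to the ring, would address. They also leave open how a methoxy group or a chlorine atom on the benzyl ring would change the read-out, and all of these readings rest on a single dose.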